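The source may report more compounds than this note shows. Statements on the series, on what has been measured and on what is new or still open speak of the compounds shown alone.

Compound 1, `N=C(S)CCn1nc(-c2ccccc2)ccc1=S`: 62.3%
Compound 2, `Cc1ccc(=O)n(CCCCCC(=N)S)n1`: 36.6%
Compound 3, `Cc1ccc(=O)n(CCCCCCC(=N)S)n1`: 29.5%

All three were tested in a functional assay on the whole organism (stomach) for inhibition, with Rattus norvegicus as the target, at a dose of 100 mg/kg by the intraduodenal route; a higher number here means more inhibition at the dose given (going by the name of the read-out), a lower number less inhibition. Compound 2 gives 36.6% and stands second highest of the three numbers. Compound 3 is its nearest neighbour: the step of a number 7.1 percentage points lower from compound 2 to compound 3 (within the scatter) stays inside the usual scatter of repeated measurements, so the two values cannot be told apart. Compound 1 is the furthest: compound 1 gives 62.3%, a number separated from compound 2 by more than the scatter. Among the measured compounds shown here, compound 1, however, differs from compound 2 in several places at once, so the two values show a gap but no single step.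

Compound 4, `N=C(S)CCCCCn1nc(-c2ccccc2)ccc1=O`, has not yet been measured. It differs from compound 2 in one way: phenyl in place of methyl on an aromatic carbon. For the measured compounds named here, no measured step exchanges methyl for phenyl in this position. Going by the values given here, the only single-change step in hand, from compound 2 to compound 3, lengthens the chain instead and stays within the scatter, so it says nothing about this exchange. Phenyl appears only in compound 1, whose other differences keep its higher value from being a clean guide. The estimate therefore starts from compound 2 and carries a wide range. Compound 4 is expected to give 46%, somewhere between 28% and 64%. The step of a number 9.4 percentage points higher from compound 2 to compound 4 (within the scatter) is thus expected to be modest and upward, without certainty that it exceeds the scatter.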

Compound 4, a percentage reported as inhibition, in the whole organism at one dose (the size of the read-out at that dose, not a potency): 91.4%
For compound 4 the middle estimate is 45.4 percentage points below the measured one; the whole stated range lies below it.
By their numbers in this assay, from the lowest: compounds 3 and 2 (each within the scatter of the next); then compound 1; then compound 4.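

In this assay, phenyl in place of methyl on this aromatic carbon gives a number 54.8 percentage points higher from compound 2 to compound 4 (beyond the scatter), so what sits at this position strongly affects the inhibition seen at the dose given. Among the compounds shown here, the only earlier single change, lengthening the chain, gave a number 7.1 percentage points lower from compound 2 to compound 3 (within the scatter) and stayed within the scatter, so the exchange of methyl for phenyl is the first single change here to move the number clearly. Nothing measured in this set explains why the exchange has such a large effect.

With only methyl and phenyl to compare at this position, the compounds shown cannot tell whether the aromatic ring itself matters or whether a larger carbon group would do the same, and a cyclohexyl or an ethyl group on the same carbon would help separate these possibilities. As far as these compounds go, it also remains open whether phenyl would bring a similar step on the longer chain of compound 3, and a reading at one dose gives the size of the effect at that dose, not a potency.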